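This account rests on a few compounds, and the source may have more. Where it says the series, first, only, none or still open, it means among the compounds named here.

Compound 1 `CC(C)(C)c1ccc(C(=O)NNc2c(Br)cccc2Br)cc1` gives > 100000 nM in a toxicity assay on MDCK cells (Canis lupus familiaris) for cytotoxicity, read by CCK-8 assay, with a stated time of 48 h (a lower number here means that less compound is tolerated, a higher number that more compound is tolerated), and that value is a limit of the assay rather than a number.
Compound 2 `COc1ccccc1C(=O)NNc1c(Br)cccc1Br` gives > 100000 nM in this assay, likewise a limit.

Compound 1 therefore stands where every value shown stands: at the limit of > 100000 nM in this assay, at which 2 of the 2 values shown sit. Among the compounds with values here, nothing measured here separates compound 1 from compound 2, and no step between measured compounds that differ in one place is available, so no measured step can guide the next one.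

Compound 3 `O=C(NNc1c(Br)cccc1Br)c1ccccc1` is the compound still to be tested in this assay. It differs from compound 1 in one place: hydrogen in place of tert-butyl on an aromatic carbon. Within the data shown here, the only measured anchor is compound 1 at > 100000 nM, a limit, so the expected step is a step that the limit leaves unreadable from compound 1 to compound 3, none beyond the usual scatter. Compound 3 is accordingly estimated to give 120000 nM in this assay, within a range of 40000 nM to 400000 nM, most probably again reported only as a limit.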

Compound 3, half-maximal cytotoxic concentration: > 100000 nM
Compound 3: a limit, no number (the forecaster's own chance of this, stated with the estimate: 75%); the middle value is on the limit's open side.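

Within the data shown here, compound 3 gives > 100000 nM in this assay, and this is a limit, so no step from compound 1 or compound 2 to compound 3 can be read. All three compounds stand together: the limit of > 100000 nM in this assay, at which 3 of the 3 values shown sit. The compounds shown leave open at what concentration, if any, each would harm these cells, and whether tert-butyl, methoxy or hydrogen makes any difference.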